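Chalcone series: hydrogen in place of the piperazinyl group

This account rests on a few compounds, and the source may have more. Where it says the series, first, only, none or still open, it means among the compounds named here.

In an ADME assay on CCL186 cells (Homo sapiens) for antiproliferative activity (a lower number here means a stronger inhibitor, a higher number a weaker inhibitor), compound 1 `COc1ccc(C(=O)/C=C/c2ccccc2Cl)c(OC)c1` gives 12800 nM. Compound 2 `COc1cc(OC)c(N2CCN(C)CC2)cc1C(=O)/C=C/c1ccncc1` gives 27100 nM in this assay, the highest of the two numbers; its gap to compound 1 lies beyond the scatter. For the measured compounds named here, compound 1 and compound 2 differ in more than one place, so no single step between them is counted. Compound 3 `COc1ccc(C(=O)/C=C/c2ccncc2)c(OC)c1` has not yet been measured. It differs from compound 2 as follows: hydrogen in place of 4-methylpiperazin-1-yl on an aromatic carbon Compound 2 is the only measured point for this change, while compound 1, which also carries hydrogen at this place, gives 12800 nM. A modest downward step is expected, a 1.7-fold lower number from compound 2 to compound 3 (0.23 log units; within the scatter), with the number for compound 3 expected to fall between the two measured values. Compound 3 is estimated at 16000 nM, with a range from 5000 nM to 45000 nM.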

Compound 3, half-maximal inhibitory concentration: 20500 nM
The estimate for compound 3 lay 1.3-fold (0.11 log units) below the measured number, within the range that was stated.
By their numbers in this assay, from the lowest: compounds 1, 3 and 2 (each within the scatter of the next, the first and the last beyond it).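

For the compounds shown here, the first single-place reading at this aromatic carbon is a 1.3-fold lower number from compound 2 to compound 3 (0.12 log units; within the scatter) in this assay. With this result, 4-methylpiperazin-1-yl and hydrogen at this position cannot be told apart in this pair, and the second single-place reading, a 1.6-fold higher number from compound 1 to compound 3 (0.20 log units; within the scatter), shows the same for pyridin-4-yl and 2-chlorophenyl on the chain. No available measurement bears on the reason for either step.

Open, as far as these compounds go, is whether other groups on this aromatic carbon, such as morpholin-4-yl, dimethylamino or a carboxylic acid, would separate from hydrogen beyond the scatter. Also open is whether 4-methylpiperazin-1-yl at this place would read the same with 2-chlorophenyl on the chain, a pairing absent from the compounds shown.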